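Removing the Side Arm: From Compound 3 to Compound 4

The compounds below may be only part of what the source reports. "The series", "measured", "known", "first", "only" and "open" are said of these compounds alone.

Of the compounds shown here, three built on one shared core have been tested in a functional assay (aorta) for antagonist activity, with Oryctolagus cuniculus as the target; on this read-out lower numbers stand for stronger inhibition and higher numbers for weaker inhibition. Compound 1 `CCCCc1ccc(CNC(=O)NC2CCCCC2)c(=O)n1Cc1ccc(-c2ccccc2-c2nn[nH]n2)cc1` gives 90 nM. Among the compounds with values here, compound 2 `CCCCNC(=O)NCc1ccc(CCCC)n(Cc2ccc(-c3ccccc3-c3nn[nH]n3)cc2)c1=O` gives 10 nM in this assay, and the single exchange between them produced a 9.0-fold lower number from compound 1 to compound 2 (0.95 log units; beyond the scatter). Compound 3 `CCCCc1ccc(CNS(C)(=O)=O)c(=O)n1Cc1ccc(-c2ccccc2-c2nn[nH]n2)cc1` gives 2 nM in this assay, the lowest number of the three; the steps leading to it were a 5.0-fold lower number from compound 2 to compound 3 (0.70 log units; beyond the scatter) and a 45-fold lower number from compound 1 to compound 3 (1.65 log units; beyond the scatter). Within this small set, exchanging the end group on the side arm moved the number well beyond the scatter each time, so that arm clearly matters to the read-out.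

Compound 4 `CCCCc1cccc(=O)n1Cc1ccc(-c2ccccc2-c2nn[nH]n2)cc1` has not yet been measured. It differs from compound 3 in one place: hydrogen in place of (methanesulfonamido)methyl on an aromatic carbon. Within the data shown here, none of the measured steps removes the arm altogether; each only swaps one end group for another, yet every one of those swaps changed the number beyond the scatter. Taking the arm away entirely is therefore expected to raise the number, probably by a modest to large amount, although the data cannot exclude a smaller effect. The expected step is a 10-fold higher number from compound 3 to compound 4 (1.00 log units; beyond the scatter). Compound 4 is expected to give about 20 nM in this assay, with a likely range from 4 nM to 150 nM.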

Compound 4, half-maximal inhibitory concentration: 4 nM
Beside the measured number, compound 4's estimate is 5.0-fold (0.70 log units) above it; the range from low to high includes it.
By their numbers in this assay, from the lowest: compounds 3 and 4 (each within the scatter of the next); then compound 2; then compound 1.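

Taking the whole (methanesulfonamido)methyl arm off this aromatic carbon gives a 2.0-fold higher number from compound 3 to compound 4 (0.30 log units; within the scatter) in this assay, so in this set a low number does not depend on having that arm here. Hydrogen in place of the two larger arms behaves differently: replacing ((butylcarbamoyl)amino)methyl gives a 2.5-fold lower number from compound 2 to compound 4 (0.40 log units; beyond the scatter) and replacing ((cyclohexylcarbamoyl)amino)methyl gives a 23-fold lower number from compound 1 to compound 4 (1.35 log units; beyond the scatter), so both of these arms carry a higher number than the bare position does. The earlier steps shown here compared arms only with one another, whereas hydrogen now gives a baseline: the two larger arms sit on the weaker side of it, while the methanesulfonamido arm cannot be told apart from it.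

As far as these compounds go, it remains open whether a small group on this carbon, such as a methyl, an aminomethyl or a carboxylic acid, would move the number away from that of compound 4 in either direction, and with only three arms on show, no trend in arm size or type can be drawn. Nothing available here explains why the arms differ in this way.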